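Fluoro Replaces Trifluoromethyl: Compound 3 Expected

A few compounds are considered here, and "the series" means these few. Any claim that something is new, unique, unknown or untested is made for them only; others in the source may bear on it.

Among the compounds with values here, compound 2 `N#CC1CN1C(=O)Nc1ccc(C(F)(F)F)cc1` stands at the higher of the two numbers measured so far: in a functional assay on A-375 cells (Homo sapiens) for inhibition (on this read-out lower numbers stand for stronger inhibition and higher numbers for weaker inhibition), compound 2 gives 11800 nM. Within the data shown here, its only neighbour, compound 1 `CCOC(=O)c1ccc(NC(=O)N2CC2C#N)cc1`, gives 5800 nM in this assay, and the single measured step, a 2.0-fold higher number from compound 1 to compound 2 (0.31 log units; beyond the scatter), lies beyond the scatter yet remains modest. Compound 3 `N#CC1CN1C(=O)Nc1ccc(F)cc1` differs from compound 2 in one place: fluoro in place of trifluoromethyl on an aromatic carbon. Among the measured compounds shown here, no measured step bears directly on this exchange of fluoro for trifluoromethyl. For the measured compounds named here, the one step known, a 2.0-fold higher number from compound 1 to compound 2 (0.31 log units; beyond the scatter), shows that exchanging a group on an aromatic carbon of this core moved the number only modestly, so a step of comparable size is expected in this assay, with no clear direction. For compound 3 the estimate is 12000 nM, expected to fall between 4000 nM and 35000 nM. This estimate corresponds to an expected step of a 1.0-fold higher number from compound 2 to compound 3 (0.01 log units; within the scatter).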

Compound 3, half-maximal inhibitory concentration: 3400 nM
Estimate against measurement, compound 3: 3.5-fold (0.55 log units) above; measured number outside the range, below it.
By their numbers in this assay, from the lowest: compounds 3 and 1 (each within the scatter of the next); then compound 2.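

The exchange of trifluoromethyl for fluoro on this aromatic carbon proved to matter in this assay, with a 3.5-fold lower number from compound 2 to compound 3 (0.54 log units; beyond the scatter) showing that the number at this position does respond to the group placed there. Fluoro and ethoxycarbonyl, by contrast, cannot be told apart, since a 1.7-fold lower number from compound 1 to compound 3 (0.23 log units; within the scatter) leaves compound 3 and compound 1 within the scatter of each other, so of the three groups shown only trifluoromethyl stands apart. Nothing available here accounts for the effect of this exchange on the read-out.

The three compounds leave open whether an amine, a carboxylic acid or a longer chain on this aromatic carbon would stay level with fluoro and ethoxycarbonyl or move the number further. They also leave open what a bare hydrogen at this place would give.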